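The source may report more compounds than this note shows. Statements on the series, on what has been measured and on what is new or still open speak of the compounds shown alone.

Measured compounds:
Compound 1 `CCCCCn1ccc2cc(/C(C)=C/C(=O)Nc3ccccc3OCCCC(=O)O)ccc21` gives 23 nM in an assay on Prostate gland for inhibition of steroid 5-alpha-reductase (Rattus norvegicus); a lower number here means a stronger inhibitor, a higher number a weaker inhibitor.
Compound 2 `CCC(C)n1ccc2cc(/C(C)=C/C(=O)Nc3ccccc3OCCCC(=O)O)ccc21` gives 67 nM in this assay.
Compound 3 `CCCCCC(CCCCC)n1ccc2cc(/C(C)=C/C(=O)Nc3ccccc3OCCCC(=O)O)ccc21` gives 25 nM in this assay.

Among the three measured compounds, compound 1 gives the lowest number in this assay; compound 3 sits within the scatter of it, while compound 2 lies beyond the scatter. The unmeasured compound 4 `CCCC(c1ccccc1)n1ccc2cc(/C(C)=C/C(=O)Nc3ccccc3OCCCC(=O)O)ccc21` differs from compound 1 in one place: 1-phenylbutyl in place of pentyl on an aromatic nitrogen.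

Among the measured compounds shown here, three measured steps bear on this change, all at the same aromatic nitrogen. Replacing pentyl with the smaller sec-butyl gave a 2.9-fold higher number from compound 1 to compound 2 (0.46 log units; beyond the scatter), a modest loss; replacing pentyl with the much larger, branched 1-pentylhexyl gave a 1.1-fold higher number from compound 1 to compound 3 (0.04 log units; within the scatter), no change beyond the scatter; and going from sec-butyl to 1-pentylhexyl gave a 2.7-fold lower number from compound 2 to compound 3 (0.43 log units; beyond the scatter). Branching at the carbon attached to the nitrogen is thus tolerated when the group is large, and only the short sec-butyl costs potency. 1-Phenylbutyl is branched and of intermediate size, so compound 4 is expected to stay close to compound 1, with a step of about a 1.3-fold higher number from compound 1 to compound 4 (0.12 log units; within the scatter), most likely within the scatter. The estimate for compound 4 in this assay is 30 nM, with a range from 12 nM to 80 nM.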

Compound 4, half-maximal inhibitory concentration: 9.1 nM
Estimate against measurement, compound 4: 3.3-fold (0.52 log units) above; measured number below the stated range.
By their numbers in this assay, from the lowest: compound 4; then compounds 1 and 3 (each within the scatter of the next); then compound 2.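

In this assay, among the compounds shown here, 1-phenylbutyl in place of pentyl on the aromatic nitrogen gives a 2.5-fold lower number from compound 1 to compound 4 (0.40 log units; beyond the scatter), so a group here can take the number below that of pentyl, which none of the earlier compounds showed. Branching at the attached carbon does not settle the outcome by itself: among the three compounds branched there, 1-phenylbutyl, the only group with a six-membered aromatic ring, gives a 2.7-fold lower number from compound 3 to compound 4 (0.44 log units; beyond the scatter) and a 7.4-fold lower number from compound 2 to compound 4 (0.87 log units; beyond the scatter). No evidence is available to explain this gain.

The compounds shown leave open whether the aromatic ring itself matters, as none carries 1-cyclohexylbutyl, the same group with a saturated ring. Also open, going by these compounds, is how a benzyl group, or a fluorine or methoxy group on the phenyl ring, would compare with 1-phenylbutyl.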